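A few compounds are considered here, and "the series" means these few. Any claim that something is new, unique, unknown or untested is made for them only; others in the source may bear on it.

Working notes on the pyridinone series.

Compound 1 `Cc1ccc(Nc2cc(Oc3c(C)cc(C)cc3C)cc(=O)[nH]2)cc1`, compound 2 `Cc1cc(C)c(Oc2cc(Nc3ccc(C#N)cc3)[nH]c(=O)c2)c(C)c1` and compound 3 `Cc1cccc(C)c1Oc1cc(Nc2ccc(C#N)cc2)[nH]c(=O)c1Cl` have been run in an ADME assay on MT4 cells (Homo sapiens) for cytotoxicity, read by MTT assay, with a stated time of 5 days; a higher number here means that more compound is tolerated, a lower number that less compound is tolerated. Compound 1 gives 37000 nM, compound 2 gives 32000 nM and compound 3 gives 29000 nM. The three numbers sit together: the step from compound 1 to compound 2 is a 1.2-fold lower number from compound 1 to compound 2 (0.06 log units; within the scatter), and the values of compound 2 and compound 3 differ by less than the usual scatter, so compound 2 stands in the middle of a flat group rather than apart from it.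

Compound 4 `Cc1cccc(C)c1Oc1cc(Nc2ccc(C#N)cc2)[nH]c(=O)c1` is not yet measured. It differs from compound 2 as follows: hydrogen in place of methyl on an aromatic carbon. The removed methyl sits on the phenoxy ring, meta to two methyl groups. For the measured compounds named here, no measured pair shows this change, and the only measured step, a change of the cyano for a methyl, lay within the scatter; the cyano-bearing pair compound 2 and compound 3 also agree. On this basis no step beyond the scatter is expected, and compound 4 is estimated at 32000 nM, range 16000 nM to 64000 nM, so that the expected step from compound 2 to compound 4 is no change at the digits printed from compound 2 to compound 4 (within the scatter).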

Compound 4, half-maximal cytotoxic concentration: 36000 nM
Compound 4: the middle estimate sits 1.1-fold (0.05 log units) below what was measured; the measured number falls inside the stated range.
By their numbers in this assay, from the lowest: compounds 3, 2, 4 and 1 (each within the scatter of the next).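

In this assay, for the compounds shown here, hydrogen in place of methyl on the aromatic carbon meta to two methyl groups gives a 1.1-fold higher number from compound 2 to compound 4 (0.05 log units; within the scatter) and is the first measured pair for this change, so this methyl can be lost without a step beyond the scatter. Hydrogen in place of chloro on an aromatic carbon gives a 1.2-fold higher number from compound 3 to compound 4 (0.09 log units; within the scatter) and adds a second place where a single change leaves the number within the scatter, so all four compounds remain one flat group.

Going by these compounds, whether an amine, a carboxylic acid or a longer chain on the aromatic carbon that lost the methyl would move the number beyond the scatter remains open. No measurement at hand speaks to why these steps stay so small.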